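The source may hold more compounds than are shown below. What is called first, only, known or untested is meant among the compounds shown, and "the series" means these compounds.

Measured compounds:
- compound 1, `Cc1ccc(-n2cc(COc3cccc(NC(=O)Nc4ccc(Cl)c(C(F)(F)F)c4)c3)nn2)cc1`, 5430 nM in a functional assay on HepG2 cells (Homo sapiens) for inhibition, read by MTT assay, with a stated time of 72 h; on this read-out lower numbers stand for stronger inhibition and higher numbers for weaker inhibition
- compound 2, `CCc1ccccc1-n1cc(COc2cccc(NC(=O)Nc3ccc(Cl)c(C(F)(F)F)c3)c2)nn1`, 3530 nM
- compound 3, `O=C(Nc1cccc(OCc2cn(-c3ccccc3Br)nn2)c1)Nc1ccc(Cl)c(C(F)(F)F)c1`, 2810 nM

Compound 3 holds the lowest of the three numbers, yet both steps that end at it, a 1.3-fold lower number from compound 2 to compound 3 (0.10 log units; within the scatter) and a 1.9-fold lower number from compound 1 to compound 3 (0.29 log units; within the scatter), lie within the scatter, so no order among the three can be claimed. Compound 4, `O=C(Nc1cccc(OCc2cn(-c3ccc(I)cc3)nn2)c1)Nc1ccc(Cl)c(C(F)(F)F)c1`, is not yet measured; it differs from compound 3 by 4-iodophenyl in place of 2-bromophenyl on an aromatic nitrogen. The two steps that altered the same phenyl group on the aromatic nitrogen, from compound 1 and from compound 2 to compound 3, were both small, as was a 1.5-fold lower number from compound 1 to compound 2 (0.19 log units; within the scatter). On that basis no step beyond the scatter is expected, so a 1.1-fold higher number from compound 3 to compound 4 (0.06 log units; within the scatter) is the estimated change. Compound 4 is therefore expected to give 3200 nM, within a range from 1400 nM to 7500 nM.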

Compound 4, half-maximal inhibitory concentration: 2690 nM
The estimate for compound 4 lay 1.2-fold (0.08 log units) above the measured number; the range from low to high includes it.
By their numbers in this assay, from the lowest: compounds 4, 3, 2 and 1 (each within the scatter of the next, the first and the last beyond it).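

In this assay, 4-iodophenyl on the aromatic nitrogen cannot be told apart from 2-bromophenyl (a 1.0-fold lower number from compound 3 to compound 4 (0.02 log units; within the scatter)) or from 2-ethylphenyl (a 1.3-fold lower number from compound 2 to compound 4 (0.12 log units; within the scatter)), since both steps lie within the scatter. Iodo in place of methyl on an aromatic carbon (a 2.0-fold lower number from compound 1 to compound 4 (0.31 log units; beyond the scatter)) is the only step among these compounds that lies beyond the scatter, and only modestly. No measurement shown gives a reason for this step. The compounds shown leave open how a phenyl carrying an amine or a carboxylic acid would read out, and whether a longer chain in place of the phenyl would change the number.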